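This account rests on a few compounds, and the source may have more. Where it says the series, first, only, none or still open, it means among the compounds named here.

Of the compounds shown here, three built on one shared core have been measured in a functional assay on ECa-109 cells (Homo sapiens) for cytotoxicity, read by MTT assay, with a stated time of 72 h; a higher number here means a weaker inhibitor, a lower number a stronger inhibitor. In this test, compound 1 `CCC(C)=C1C(=O)N(c2ccc(Cl)cc2)N(c2ccc(Cl)cc2)C1=O` gives 41100 nM and compound 2 `O=C1C(=Cc2ccc(F)cc2)C(=O)N(c2ccc(Cl)cc2)N1c1ccc(Cl)cc1` gives 35600 nM, two values that lie close together. Compound 3 `COc1ccc(C=C2C(=O)N(c3ccc(Cl)cc3)N(c3ccc(Cl)cc3)C2=O)cc1` reads > 128000 nM, which is a limit and not a number.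

The next compound, compound 4 `O=C1C(=Cc2ccc(Cl)cc2Cl)C(=O)N(c2ccc(Cl)cc2)N1c1ccc(Cl)cc1`, has not yet been measured. It differs from compound 3 in one place: 2,4-dichlorophenyl in place of 4-methoxyphenyl on a double-bonded chain carbon bound to a double-bonded ring carbon. In words, 2,4-dichlorophenyl stands in place of 4-methoxyphenyl on a double-bonded chain carbon bound to a double-bonded ring carbon.

Among the compounds with values here, only one measured step bears on this change: an at least 3.5-fold higher number from compound 2 to compound 3 (0.55 log units; beyond the scatter), with methoxy in place of fluoro on an aromatic carbon. That step lies beyond the scatter, but a single step is thin ground for a forecast. The change to compound 4 takes the methoxy away again, so its number is expected to come back towards that of compound 2, at 35600 nM.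

The expected change is an at least 4.0-fold lower number from compound 3 to compound 4 (0.60 log units; beyond the scatter), towards a lower number and so a stronger inhibitor. For compound 4 the estimated value is 32000 nM, with an expected range of 11000 nM to 95000 nM.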

Compound 4, half-maximal inhibitory concentration: 60200 nM
The estimate for compound 4 lay 1.9-fold (0.27 log units) below the measured number; the range from low to high includes it.
By their numbers in this assay, from the lowest: compounds 2, 1 and 4 (each within the scatter of the next). At a limit, above all of these: compound 3.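

In this assay, placing 2,4-dichlorophenyl on this double-bonded chain carbon bound to a double-bonded ring carbon gives an at least 2.1-fold lower number from compound 3 to compound 4 (0.32 log units; beyond the scatter), so a second group besides 4-fluorophenyl now reads clearly apart from 4-methoxyphenyl. Comparing the two halogen-bearing rings at this same place gives a 1.7-fold higher number from compound 2 to compound 4 (0.23 log units; within the scatter), which means that 4-fluorophenyl and 2,4-dichlorophenyl cannot be told apart here, even though their rings carry different substituents in different numbers. Compound 3 reads as a limit and not as a number, so the first step sets only a minimum for the change, and its true size remains unknown because of this limit: the limit of > 128000 nM in this assay, at which 1 of the 4 values shown sits.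

2,4-Dichlorophenyl differs from 4-fluorophenyl in more than one way. 4-Chlorophenyl would be needed to separate the effect of each chlorine. From the compounds shown here alone, whether a ring bearing an amine or a carboxylic acid would read like compound 3 or like compound 2 also stays open, as does the question of whether methoxy alone sets compound 3 apart.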